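The source may report more compounds than this note shows. Statements on the series, on what has been measured and on what is new or still open speak of the compounds shown alone.

Compound 1 `Clc1cccc(Nc2ncnc3ccc(NCc4ccc5c(c4)OCCCO5)cc23)c1` gives the lower of the two numbers recorded in a functional assay on B16-F10 cells (Mus musculus) for antiproliferative activity, read by WST assay, with a stated time of 48 h; on this read-out higher numbers stand for weaker inhibition and lower numbers for stronger inhibition: compound 1 gives 2.14 ug/mL. Its nearest neighbour on this scale is compound 2 `O=C(Nc1ccc2ncnc(Nc3cccc(Br)c3)c2c1)C1COc2ccccc2O1`, which gives 50.1 ug/mL, a gap well beyond the usual scatter. Compound 3 `O=C(Nc1ccc2ncnc(Nc3cccc(Cl)c3)c2c1)C1COc2ccccc2O1` reaches only a limit of this assay, > 100 ug/mL.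

Among the compounds with values here, the pair of compounds 2 and 3 differs in one place, and that step, an at least 1.9-fold higher number from compound 2 to compound 3 (0.30 log units; that floor lies within the scatter), is the only measured guide to swapping these two halogens, though its floor lies within the scatter.

Compound 4 `Brc1cccc(Nc2ncnc3ccc(NCc4ccc5c(c4)OCCCO5)cc23)c1` differs from compound 1 by the reverse exchange: bromo in place of chloro on an aromatic carbon. From the step seen from compound 2 to compound 3, the bromo compound is expected to give a number that is similar or slightly lower, with a step of a 1.4-fold lower number from compound 1 to compound 4 (0.15 log units; within the scatter) estimated. Compound 4 is therefore expected to give about 1.5 ug/mL in this assay, with a likely range from 0.6 ug/mL to 4.5 ug/mL.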

Compound 4, half-maximal inhibitory concentration: 1.99 ug/mL
Compound 4: middle estimate off by 1.3-fold (0.12 log units), on the low side; measured number inside the range.
By their numbers in this assay, from the lowest: compounds 4 and 1 (each within the scatter of the next); then compound 2. At a limit, above all of these: compound 3.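

In this assay, the exchange at this position can now be read as a full step rather than a floor: bromo in place of chloro gives a 1.1-fold lower number from compound 1 to compound 4 (0.03 log units; within the scatter). On the core of compound 1, 3-chlorophenyl and 3-bromophenyl therefore cannot be told apart by this read-out. The earlier pair could not show this, and whether the change behaves alike on the two cores stays undecided: the same change on two cores in this assay, an at least 1.9-fold higher number (0.30 log units; that floor lies within the scatter) from compound 2 to compound 3 and a 1.1-fold higher number (0.03 log units; within the scatter) from compound 4 to compound 1; the limit leaves it open whether they differ

Going by these compounds, how a group other than these two halogens, such as fluoro, methoxy or a nitrile, would read at this position on the core of compound 1 remains open. The true size of the step to compound 3 also stays open because compound 3 stands at a limit of the assay, not at a number: the limit of > 100 ug/mL in this assay, at which 1 of the 4 values shown sits.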